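Swapping benzyl for an aromatic carbonyl group on compound 2

The source may hold more compounds than are shown below. What is called first, only, known or untested is meant among the compounds shown, and "the series" means these compounds.

Compound 1 `COc1cc2nccc(Oc3ccc4c(NC(=O)Nc5ccc(C(F)(F)F)cc5Cl)nn(C)c4c3)c2cc1OC`: > 1000 nM
Compound 2 `COc1cc2nccc(Oc3ccc4c(NCc5ccccc5)nn(C)c4c3)c2cc1OC`: > 1000 nM

In a functional assay on HUVEC cells (Homo sapiens) for inhibition, with stated times of 2 h and 72 h (a lower number here means a stronger inhibitor, a higher number a weaker inhibitor), compound 2 gives > 1000 nM, which is a limit and not a number. Compound 2 therefore stands at the limit of > 1000 nM in this assay, at which 2 of the 2 values shown sit, and no exact potency is known for either compound. Compound 3 `COc1cc2nccc(Oc3ccc4c(NC(=O)c5ccc(C(F)(F)F)cc5)nn(C)c4c3)c2cc1OC` carries (4-(trifluoromethyl)phenyl)carbonyl in place of benzyl on a nitrogen on an aromatic ring. Resting on (the limit of > 1000 nM in this assay, at which 2 of the 2 values shown sit), no change beyond the scatter is expected in either direction. The expected step, a step that the limit leaves unreadable from compound 2 to compound 3, is therefore small. For compound 3 the estimated value is 1500 nM, with an expected range of 300 nM to 8000 nM.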

Compound 3, half-maximal inhibitory concentration: > 1000 nM
Compound 3 was reported as a limit (the forecaster's own chance of this, stated with the estimate: 70%); the middle value does not contradict the limit.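

No step can be read between compound 1, compound 2 and compound 3 in this assay, because each result is a limit and not a number: the limit of > 1000 nM in this assay, at which 3 of the 3 values shown sit.

The compounds shown leave open how strongly each one inhibits, and whether either change alters potency at all.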